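The compounds below may be only part of what the source reports. "The series", "measured", "known", "first", "only" and "open" are said of these compounds alone.

Measured so far:
compound 1 `CC1CCCCC1C(=O)N1CC(c2nc(-c3cccc(F)c3)no2)C1`: > 10000 nM
compound 2 `O=C(N1CCCCC1)N1CC(c2nc(-c3cccc(Cl)c3)no2)C1`: > 10000 nM

In an assay on HEK293 cells for negative allosteric modulation of metabotropic glutamate receptor 5 (Homo sapiens), read by FLIPR (on this read-out higher numbers stand for weaker inhibition and lower numbers for stronger inhibition), compound 1 gives only a limit, > 10000 nM. Compound 2 likewise returns only a limit in this assay, > 10000 nM. Compound 2 therefore stands at the limit of > 10000 nM in this assay, at which 2 of the 2 values shown sit, and the two measured compounds cannot be ordered against each other from these numbers. Compound 3 `COC1CCCN(C(=O)N2CC(c3nc(-c4cccc(Cl)c4)no3)C2)C1` differs from compound 2 by methoxy in place of hydrogen on a saturated ring carbon. Among the compounds with values here, no measured step shows what such a change does. The expected step that the limit leaves unreadable from compound 2 to compound 3 is none beyond the scatter, with a limit again the likelier outcome. The estimate for compound 3 is 15000 nM, within 3000 nM to 60000 nM.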

Compound 3, half-maximal inhibitory concentration: 1830 nM
Beside the measured number, compound 3's estimate is 8.2-fold (0.91 log units) above it; the measured number lies below the stated range.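

In this assay, the change from piperidin-1-yl to 3-methoxypiperidin-1-yl gives an at least 5.4-fold lower number from compound 2 to compound 3 (0.73 log units; beyond the scatter). This saturated ring carbon, two ring bonds from the ring nitrogen, is therefore a position where a methoxy group can move the read-out beyond the scatter, and compound 3 is the only compound shown with a number rather than a limit. The step is a lower bound, and the other two compounds offer no numerical comparison: the limit of > 10000 nM in this assay, at which 2 of the 3 values shown sit.

As far as these compounds go, whether a hydroxyl or an ethyl group on this carbon would give a similar step remains open. So does the outcome of moving the methoxy group to another carbon of the same ring.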